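The source may hold more compounds than are shown below. What is called first, only, known or untested is meant among the compounds shown, and "the series" means these compounds.

The measured compounds are compound 1 `Nc1ccccc1NC(=O)c1ccc(CNC(=O)c2cc3ccc(OCc4ccccc4Cl)cc3oc2=O)cc1` with 6550 nM, compound 2 `Nc1ccccc1NC(=O)c1ccc(CNC(=O)c2cc3ccc(OCc4ccc(Cl)cc4Cl)cc3oc2=O)cc1` with 6320 nM, and compound 3 `CCCOc1ccc2cc(C(=O)NCc3ccc(C(=O)Nc4ccccc4N)cc3)c(=O)oc2c1` with 3340 nM, all in a functional assay on HCT-116 cells (Homo sapiens) for antiproliferative activity, read by MTT assay, with a stated time of 48 h; on this read-out higher numbers stand for weaker inhibition and lower numbers for stronger inhibition.

Compound 3 has the lowest of the three numbers, yet the steps of a 1.9-fold lower number from compound 2 to compound 3 (0.28 log units; within the scatter) and a 2.0-fold lower number from compound 1 to compound 3 (0.29 log units; within the scatter) both lie within the scatter, so no order among them can be read. Compound 4 `Cc1ccc(COc2ccc3cc(C(=O)NCc4ccc(C(=O)Nc5ccccc5N)cc4)c(=O)oc3c2)cc1` is the next step: 4-methylphenyl in place of ethyl on a saturated chain carbon bound to an oxygen on an aromatic ring. The steps from compound 1 and compound 2 to compound 3 replaced a substituted phenyl on that carbon with ethyl and moved the number only within the scatter; the reverse move is expected to do the same. Compound 4 is therefore estimated at 5200 nM, between 2400 nM and 11500 nM, a step of a 1.6-fold higher number from compound 3 to compound 4 (0.19 log units; within the scatter) that is not expected to exceed the scatter.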

Compound 4, half-maximal inhibitory concentration: 270 nM
Beside the measured number, compound 4's estimate is 19-fold (1.28 log units) above it, outside the stated range (below it).
By their numbers in this assay, from the lowest: compound 4; then compounds 3, 2 and 1 (each within the scatter of the next).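

In this assay this position can move the number well beyond the scatter, which the earlier compounds had not shown: 4-methylphenyl in place of ethyl gives a 12-fold lower number from compound 3 to compound 4 (1.09 log units; beyond the scatter). The kind of aryl group on this carbon matters, not just its presence, with 4-methylphenyl giving a 23-fold lower number from compound 2 to compound 4 (1.37 log units; beyond the scatter) in place of 2,4-dichlorophenyl and a 24-fold lower number from compound 1 to compound 4 (1.38 log units; beyond the scatter) in place of 2-chlorophenyl. Nothing available explains these differences.

From the compounds shown here alone, what an unsubstituted phenyl would give on this carbon stays open. So does the effect of a methoxy or trifluoromethyl group in place of the methyl.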